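The source may hold more compounds than are shown below. What is called first, only, known or untested is meant among the compounds shown, and "the series" means these compounds.

Measured so far:
compound 1, `CC(Oc1ccccc1C=O)C1=NCCN1` — 0.5
compound 2, `CC(C)Oc1ccccc1OC(C)C1=NCCN1` — 0.5
compound 3, `CC(Oc1ccccc1S(C)(=O)=O)C1=NCCN1` — 0.45

Three compounds share a core and differ only in the group on one aromatic carbon. In an assay on CHO cells with Alpha-2B adrenergic receptor (Homo sapiens) as the target (on this read-out lower numbers stand for smaller maximal responses and higher numbers for larger maximal responses), compound 1 gives 0.5, compound 2 gives 0.5 and compound 3 gives 0.45. Compound 3 stands alongside the other two rather than apart from them: a number 0.050 lower from compound 1 to compound 3 (within the scatter) and a number 0.050 lower from compound 2 to compound 3 (within the scatter). The remaining pair is the same: no change at the digits printed from compound 1 to compound 2 (within the scatter). Across formyl, isopropoxy and methylsulfonyl, the maximal response therefore does not move beyond the scatter.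

Compound 4, `CC(=O)c1ccccc1OC(C)C1=NCCN1`, has not yet been measured. Relative to compound 3 the change is acetyl in place of methylsulfonyl on an aromatic carbon. Within the data shown here, the steps that bear on it are those into compound 3 from compound 1 and from compound 2, both within the scatter, and compound 1 itself carries a one-carbon carbonyl group at the same carbon, close in kind to the acetyl entering here. With three different groups at this position all giving the same response within the scatter, the expected step is a number 0.050 higher from compound 3 to compound 4 (within the scatter), none beyond the scatter, in either direction. Compound 4 is accordingly expected at 0.5, within 0.38 to 0.62.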

Compound 4, intrinsic activity: the largest response reached, as a fraction of the reference agonist's: 0.6
Estimate against measurement, compound 4: 0.10 below; measured number inside the range.
By their numbers in this assay, from the lowest: compounds 3, 1, 2 and 4 (each within the scatter of the next, the first and the last beyond it).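

In this assay, among these compounds, this aromatic carbon no longer reads as wholly indifferent to its substituent: acetyl in place of methylsulfonyl gives a number 0.15 higher from compound 3 to compound 4 (beyond the scatter) and is the one change in the set that clears the scatter. The separation belongs to that pair alone: isopropoxy giving way to acetyl gives a number 0.10 higher from compound 2 to compound 4 (within the scatter) and methyl in place of hydrogen on the carbonyl carbon gives a number 0.10 higher from compound 1 to compound 4 (within the scatter) and so compound 1 and compound 2 stay within the scatter of compound 4, while only compound 3 and compound 4 stand apart. No supporting measurement accompanies this result, so the separation stands without an explanation.

Going by these compounds, whether the separation follows from the leaving of methylsulfonyl or from the entry of acetyl stays open, and a single pair cannot settle it. Also open, on these data alone, is where a longer acyl chain such as propionyl, an amine or a carboxylic acid on this aromatic carbon would fall relative to compound 3 and compound 4, and whether any such group would take the maximal response outside the span these four compounds cover.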